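Swapping isopropyl for butyl: a small step expected

This account rests on a few compounds, and the source may have more. Where it says the series, first, only, none or still open, it means among the compounds named here.

compound 1 `C=C1C(=O)OC[C@@H]1CCOC(=O)Nc1ccc(C(C)C)cc1` gives 1580 nM
compound 2 `C=C1C(=O)OC[C@H]1CCOC(=O)Nc1ccc(C(=O)OCCCC)cc1` gives 430 nM

In a functional assay on RAW264.7 cells (Mus musculus) for inhibition, with a stated time of 30 min (on this read-out lower numbers stand for stronger inhibition and higher numbers for weaker inhibition), compound 1 stands higher of the two at 1580 nM, making it the weaker inhibitor, and compound 2 lies lower by more than the usual scatter. Compound 3 `C=C1C(=O)OC[C@@H]1CCOC(=O)Nc1ccc(CCCC)cc1` has not yet been measured. It carries butyl in place of isopropyl on an aromatic carbon, para to a large group: butyl in place of isopropyl on an aromatic carbon. Among the measured compounds shown here, no measured pair of compounds shows this single change, so the expectation is loose. A small move toward a lower number is expected in this assay, staying within the scatter. The expected change is a 1.6-fold lower number from compound 1 to compound 3 (0.20 log units; within the scatter). For compound 3 the estimated value is 1000 nM, with an expected range from 350 nM to 2600 nM.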

Compound 3, half-maximal inhibitory concentration: 1230 nM
Beside the measured number, compound 3's estimate is 1.2-fold (0.09 log units) below it; low and high end bracket the measured number.
By their numbers in this assay, from the lowest: compound 2; then compounds 3 and 1 (each within the scatter of the next).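

In this assay butyl in place of isopropyl on this aromatic carbon, para to a large group, gives a 1.3-fold lower number from compound 1 to compound 3 (0.11 log units; within the scatter) and so the two groups cannot be told apart at this position. A straight chain and a branched one of similar size are thus tolerated equally here. Among the compounds shown here, nothing measured so far explains this result.

On these data alone, whether a longer chain, an amine or a carboxylic acid on this carbon would shift the number beyond the scatter remains open. Compound 2 differs from both compounds in more than one place, so its value says nothing about this change alone.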